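The compounds below may be only part of what the source reports. "The series", "measured", "known", "first", "only" and "open" are said of these compounds alone.

Compound 1 `C[C@@H](O)[C@H]1C(=O)N2C(C(=O)OCOC(=O)C(C)(C)C)=C(S[C@@H]3CN[C@H](C(=O)Nc4cccc(C(=O)O)c4)C3)[C@H](C)[C@H]12` is one of three compounds that have been run in an ADME assay for metabolic stability, read by LC-MS, with a stated time of 3 h, at pH 6.5, tested at 50 uM; a lower number here means that less of the compound is left, a higher number that more of the compound is left. In this assay compound 1 gives > 95%, which is a limit of the assay and not a number. Compound 2 `COC(=O)C1=C(S[C@@H]2CN[C@H](C(=O)Nc3cccc(C(=O)OC)c3)C2)[C@H](C)[C@@H]2[C@@H]([C@@H](C)O)C(=O)N12` likewise reaches a limit, giving > 95% in this assay. Compound 3 `CCOC(=O)C1=C(S[C@H]2C[C@@H](C(=O)Nc3cccc(C(=O)OCC)c3)N(Cc3oc(=O)oc3C)C2)[C@H](C)[C@@H]2[C@@H]([C@@H](C)O)C(=O)N12` gives > 95% in this assay, again a limit. So compound 1 stands at the same limit as the other two, as the limit of > 95% in this assay, at which 3 of the 3 values shown sit, shows, and no step between measured compounds can be sized. Compound 4 `COC(=O)OCOC(=O)C1=C(S[C@@H]2CN[C@H](C(=O)Nc3cccc(C(=O)O)c3)C2)[C@H](C)[C@@H]2[C@@H]([C@@H](C)O)C(=O)N12` is not yet measured; it differs from compound 1 by methoxy in place of tert-butyl on a carbonyl carbon. With nothing measured separating the three compounds, the step of a number at least 3 percentage points lower from compound 1 to compound 4 (that floor lies within the scatter) is expected to be small, a decline of at most modest size. Compound 4 is therefore estimated at 92%, within 75% to 99%.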

Compound 4, percent of the compound remaining: > 95%
Compound 4 was reported as a limit (the forecaster's own chance of this, stated with the estimate: 60%); middle value at least 3 percentage points away from the limit.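

Within the data shown here, compound 1 and compound 4 both stand at a limit of this assay, not at a number, so no step between them can be read. The compounds shown leave open whether methoxy in place of tert-butyl changes the percent remaining at all, since the values give no number to compare: the limit of > 95% in this assay, at which 4 of the 4 values shown sit.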